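A few compounds are considered here, and "the series" means these few. Any claim that something is new, unique, unknown or untested is made for them only; others in the source may bear on it.

Compound 1 `[O-][n+]1nc(NCCN2CCCCC2)[n+]([O-])c2cc(Cl)ccc21` serves as the reference point of this small set. In a physicochemical assay for solubility, in the presence of a further agent that is not named here (on this read-out higher numbers stand for higher solubility and lower numbers for lower solubility), compound 1 gives 3200000 nM. Compound 2 `CCCN(CCC)CCNc1n[n+]([O-])c2ccc(Cl)cc2[n+]1[O-]` carries dipropylamino in place of piperidin-1-yl on a saturated chain carbon, two bonds along the chain from a nitrogen on an aromatic ring; in this assay compound 2 gives 600000 nM, and the step is a 5.3-fold lower number from compound 1 to compound 2 (0.73 log units; beyond the scatter). Compound 3 `CC(C)(C)c1ccc2c(c1)[n+]([O-])c(NCCN1CCCCC1)n[n+]2[O-]` differs from compound 1 in one place only; in this assay compound 3 gives 28000000 nM, the highest of the three numbers, reached as an 8.8-fold higher number from compound 1 to compound 3 (0.94 log units; beyond the scatter).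

Compound 4 `CCCN(CCC)CCNc1n[n+]([O-])c2ccc(C(C)(C)C)cc2[n+]1[O-]` has not yet been measured. For the measured compounds named here, it differs from compound 3 by dipropylamino in place of piperidin-1-yl on a saturated chain carbon, two bonds along the chain from a nitrogen on an aromatic ring, the same change as the one from compound 1 to compound 2, at a place described in identical words. The two cores on which this change is made differ by tert-butyl in place of chloro on an aromatic carbon.

Going by the values given here, the step from compound 3 to compound 4 is expected to resemble the one seen for compound 1, because a 5.3-fold lower number from compound 1 to compound 2 (0.73 log units; beyond the scatter) is the only instance of this change so far, so a step of about a 5.3-fold lower number from compound 3 to compound 4 (0.72 log units; beyond the scatter) is estimated. Compound 4 is therefore expected to give roughly 5300000 nM in this assay, with a plausible range from 2000000 nM to 14000000 nM.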

Compound 4, solubility: 32000000 nM
Estimate against measurement, compound 4: 6.0-fold (0.78 log units) below; measured number outside the range, above it.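

Dipropylamino in place of piperidin-1-yl in this assay gives a 5.3-fold lower number from compound 1 to compound 2 (0.73 log units; beyond the scatter) on the core of compound 1 but a 1.1-fold higher number from compound 3 to compound 4 (0.06 log units; within the scatter) on the core of compound 3, so the step seen on the chloro core did not carry over to the tert-butyl core. Tert-butyl in place of chloro gives an 8.8-fold higher number from compound 1 to compound 3 (0.94 log units; beyond the scatter) with piperidin-1-yl and a 53-fold higher number from compound 2 to compound 4 (1.73 log units; beyond the scatter) with dipropylamino, so in these four compounds the size of each step differs with the group at the other site. With a single pair on each core, this shows that the step need not transfer, not how it would behave on a third core, and nothing available explains the difference between the two cores.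

Still open, on these data alone, is whether a core bearing trifluoromethyl or methoxy in place of chloro or tert-butyl would follow compound 1 or compound 3 in this change. Also open, as far as these compounds go, is how morpholin-4-yl or diethylamino in place of piperidin-1-yl would behave on either core.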